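A second cyano group and cell toxicity

This account rests on a few compounds, and the source may have more. Where it says the series, first, only, none or still open, it means among the compounds named here.

Measured in a toxicity assay on MT4 cells (Homo sapiens) for cytotoxicity, read by MTT assay (on this read-out lower numbers stand for higher toxicity in this test and higher numbers for lower toxicity in this test), so far:
compound 1 `Cc1cc(-c2ccccc2)cc(C)c1Oc1cc(N)nc(Nc2ccc(C#N)cc2)n1` gives 25600 nM
compound 2 `Cc1cc(-c2ccc(Cl)cc2)cc(C)c1Oc1cc(N)nc(Nc2ccc(C#N)cc2)n1` gives 21500 nM
compound 3 `Cc1cc(-c2ccccc2C#N)cc(C)c1Oc1cc(N)nc(Nc2ccc(C#N)cc2)n1` gives 25400 nM

These numbers lie within the scatter of one another, so compound 3, at 25400 nM, has no distinct rank among them.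

The next compound, compound 4 `Cc1cc(-c2ccc(C#N)c(C#N)c2)cc(C)c1Oc1cc(N)nc(Nc2ccc(C#N)cc2)n1`, has 3,4-dicyanophenyl in place of 2-cyanophenyl on an aromatic carbon of compound 3: 3,4-dicyanophenyl in place of 2-cyanophenyl on an aromatic carbon.

Going by the values given here, three measured steps bear on this change. They alter the same group. Adding cyano gave a 1.0-fold lower number from compound 1 to compound 3 (0.00 log units; within the scatter), adding chloro gave a 1.2-fold lower number from compound 1 to compound 2 (0.08 log units; within the scatter), and exchanging the two substituted rings gave a 1.2-fold higher number from compound 2 to compound 3 (0.07 log units; within the scatter). All three stayed within the scatter. Among the compounds with values here, no measured compound carries two cyano groups on this ring, so the evidence is indirect. Even so, no step beyond the scatter is expected in this assay, and neither direction is favoured.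

The expected change is a 1.1-fold lower number from compound 3 to compound 4 (0.04 log units; within the scatter).

For compound 4, the estimated value is 23000 nM, with an expected range from 10000 nM to 50000 nM.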

Compound 4, half-maximal cytotoxic concentration: 17600 nM
Compound 4: the middle estimate sits 1.3-fold (0.12 log units) above what was measured; the range from low to high includes it.
By their numbers in this assay, from the lowest: compounds 4, 2, 3 and 1 (each within the scatter of the next).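

In this assay, going by these compounds alone, the 3,4-dicyanophenyl ring is the first here to carry two nitrile groups, and its steps can be read against all three earlier rings. They are a 1.4-fold lower number from compound 3 to compound 4 (0.16 log units; within the scatter) and a 1.2-fold lower number from compound 2 to compound 4 (0.09 log units; within the scatter) and also a 1.5-fold lower number from compound 1 to compound 4 (0.16 log units; within the scatter) in the comparison with the unsubstituted phenyl ring. Even with a second nitrile group, then, this position shows no difference beyond the scatter among the four compounds, which extends the earlier picture from one added group to two.

On these data alone, whether an amine or a carboxylic acid at this position would produce a step beyond the scatter remains open, as all the groups compared here are chloro or nitrile substituents on a phenyl ring. No measurement shown here explains why these numbers stay so close together.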